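Aryl group on the ring nitrogen: methyl to fluorine

This account rests on a few compounds, and the source may have more. Where it says the series, first, only, none or still open, it means among the compounds named here.

Measured in a functional assay on HepG2 cells (Homo sapiens) for antiproliferative activity, read by MTT assay, with a stated time of 24 h; on this read-out lower numbers stand for stronger inhibition and higher numbers for weaker inhibition:
Compound 1 `Cc1ccccc1-n1cc(-c2ccc(NS(=O)(=O)c3c[nH]c(=O)[nH]c3=O)cc2)nn1` gives 14500 nM.
Compound 2 `Cc1cccc(-n2cc(-c3ccc(NS(=O)(=O)c4c[nH]c(=O)[nH]c4=O)cc3)nn2)c1` gives only a limit, > 20000 nM.
Compound 3 `Cc1ccc(-n2cc(-c3ccc(NS(=O)(=O)c4c[nH]c(=O)[nH]c4=O)cc3)nn2)cc1` gives 11600 nM.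

Compound 3 stands lowest of the two numbers; compound 1 is nearest, with a 1.3-fold lower number from compound 1 to compound 3 (0.10 log units; within the scatter). Compound 2 is a limit of this assay, as the limit of > 20000 nM in this assay, at which 1 of the 3 values shown sits, shows, and an at least 1.7-fold lower number from compound 2 to compound 3 (0.23 log units; that floor lies within the scatter) rests on that floor. Compound 4 `O=c1[nH]cc(S(=O)(=O)Nc2ccc(-c3cn(-c4ccccc4F)nn3)cc2)c(=O)[nH]1` carries the change (2-fluorophenyl in place of 4-methylphenyl on an aromatic nitrogen). Every measured step only moves the methyl about the phenyl ring; none swaps methyl for fluorine, and all three (an at least 1.3-fold higher number from compound 1 to compound 2 (0.13 log units; that floor lies within the scatter), a 1.3-fold lower number from compound 1 to compound 3 (0.10 log units; within the scatter), an at least 1.7-fold lower number from compound 2 to compound 3 (0.23 log units; that floor lies within the scatter)) sit within the scatter. The expected step is therefore a 1.1-fold higher number from compound 3 to compound 4 (0.05 log units; within the scatter), nothing beyond the scatter. For compound 4 the estimate is 13000 nM, expected between 6000 nM and 26000 nM.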

Compound 4, half-maximal inhibitory concentration: > 20000 nM
Compound 4 gave a limit, no number (the forecaster's own chance of this, stated with the estimate: 20%); at least 1.5-fold (0.18 log units) between middle value and limit.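

With 2-fluorophenyl on the aromatic nitrogen, compound 4 gives only a limit in this assay, not a number, and the series now holds a second such result: the limit of > 20000 nM in this assay, at which 2 of the 4 values shown sit.

The readable floors, an at least 1.7-fold higher number from compound 3 to compound 4 (0.23 log units; that floor lies within the scatter) and an at least 1.3-fold higher number from compound 1 to compound 4 (0.13 log units; that floor lies within the scatter), do not establish a real loss from either change. The step between compound 2 and compound 4 cannot be read, since both are limits.

From the compounds shown here alone, it remains open whether an amine or a carboxylic acid on this phenyl ring, in place of methyl or fluoro, would give a measurable number. Whether any change here moves activity beyond the scatter is also unresolved.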